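Amide to Sulfonamide on a Palmitoyl Anilide Series

The source may hold more compounds than are shown below. What is called first, only, known or untested is meant among the compounds shown, and "the series" means these compounds.

Going by the values given here, the three compounds measured so far share a long palmitoyl chain on one end. Compound 1, `CCCCCCCCCCCCCCCC(=O)NCCC(=O)Nc1ccc(C(=O)N[C@@H](CCSC)C(=O)OC)cc1`, gives 15% in an in vitro assay on Sf9 cells for inhibition of CAAX prenyl protease 2 (Homo sapiens), tested at 10 uM; on this read-out higher numbers stand for more inhibition at the one concentration tested (going by the name of the read-out) and lower numbers for less inhibition. Compound 2, `CCCCCCCCCCCCCCCC(=O)NCC(=O)Nc1ccc(C(=O)N[C@@H](CCSC)C(=O)OC)cc1`, gives 22% in this assay. Compound 3, `CCCCCCCCCCCCCCCC(=O)NCCC(=O)Nc1cccc(C(=O)Nc2cccc(C)c2C)c1`, gives 11% in this assay, a number that compound 1 matches within the usual scatter, whereas compound 2 sits beyond the scatter on the higher side. Compound 4, `CCCCCCCCCCCCCCCC(=O)NCCC(=O)Nc1cccc(S(=O)(=O)Nc2cccc(C)c2C)c1`, is the next one to be tested and differs from compound 3 in a single place: (2,3-dimethylphenyl)sulfamoyl in place of (2,3-dimethylphenyl)carbamoyl on an aromatic carbon. Among the compounds with values here, no measured pair shows what this exchange does, so no step has been observed for it. Given that the three known numbers all sit low and close together, the step from compound 3 to compound 4 is expected to be small, with no change beyond the scatter in either direction, estimated as a number 2 percentage points higher from compound 3 to compound 4 (within the scatter). Compound 4 is accordingly expected to give about 13% in this assay, in the range 2% to 30%.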

Compound 4, a percentage reported as inhibition, at one concentration (the size of the read-out at that concentration, not a potency): 18%
Beside the measured number, compound 4's estimate is 5 percentage points below it, within the range that was stated.
By their numbers in this assay, from the lowest: compounds 3, 1, 4 and 2 (each within the scatter of the next, the first and the last beyond it).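

In this assay the exchange of the (2,3-dimethylphenyl)carbamoyl group for the (2,3-dimethylphenyl)sulfamoyl group, on an aromatic carbon meta to a large group, comes to a number 7 percentage points higher from compound 3 to compound 4 (within the scatter), so this change at this position cannot be told apart from the scatter. Going by these compounds alone, this is the first single-place step, as the earlier compounds differ from one another in more than one place and could not show what happens at this position. Nothing measured here offers an explanation for the result.

The compounds shown leave open how a carboxylic acid or an amine would read in this assay if placed on the same aromatic carbon. They also leave open whether a shorter chain in place of the palmitoyl chain would change the number on this core.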